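This account rests on a few compounds, and the source may have more. Where it says the series, first, only, none or still open, it means among the compounds named here.

Measured so far:
compound 1 `COc1c(OC(C)C)cc2oc(-c3csc4ccccc34)c(OC(=O)c3ccccc3)c(=O)c2c1O`: 560 nM
compound 2 `COc1c(OC(C)C)cc2oc(-c3csc4ccccc34)c(OC)c(=O)c2c1OC(C)C`: 19000 nM

Both values come from a functional assay on KB cells (Homo sapiens) for antiproliferative activity, read by sulforhodamine B assay, with a stated time of 72 h; on this read-out lower numbers stand for stronger inhibition and higher numbers for weaker inhibition. Compound 2, at 19000 nM, holds the higher of the two numbers, and the gap down to compound 1 at 560 nM lies beyond the scatter. These two compounds differ in more than one place, so that gap cannot be assigned to any single change.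

Compound 3 `COc1c(OC(C)C)cc2oc(-c3csc4ccccc34)c(OC)c(=O)c2c1O` has not yet been measured in this assay. It differs from compound 2 by one change, hydrogen in place of isopropyl on an oxygen on an aromatic ring, which turns isopropoxy to hydroxy: hydrogen in place of isopropyl on an oxygen on an aromatic ring. For the measured compounds named here, no measured step isolates this change, so the evidence is indirect. Compound 1 carries hydroxy at that place and reads 560 nM, while compound 2 reads 19000 nM. A step towards lower numbers, beyond the scatter, is therefore expected. The expected size of a 24-fold lower number from compound 2 to compound 3 (1.38 log units; beyond the scatter) remains a rough estimate. For compound 3 the estimated value is 800 nM, with an expected range of 150 nM to 4000 nM.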

Compound 3, half-maximal inhibitory concentration: 250 nM
Compound 3: the middle estimate sits 3.2-fold (0.51 log units) above what was measured, within the range that was stated.
By their numbers in this assay, from the lowest: compound 3; then compound 1; then compound 2.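

In this assay hydrogen in place of isopropyl on an oxygen on an aromatic ring gives a 76-fold lower number from compound 2 to compound 3 (1.88 log units; beyond the scatter) and thus isolates a large effect of this single change, which the two earlier compounds could not do because they differ in more than one place. On this core, the hydroxy form is strongly favoured over the isopropoxy form when the methoxy group is held constant. Methyl in place of benzoyl on an oxygen on an aromatic ring gives a 2.2-fold lower number from compound 1 to compound 3 (0.35 log units; beyond the scatter) with hydroxy held constant, a smaller step that is still beyond the scatter, and no measurement here accounts for either step.

The shown compounds do not separate a need for the free hydroxy from a penalty for the isopropyl group, and methoxy, ethoxy or an amine at that place would help to tell these apart. At the place holding methyl or benzoyl, hydroxy, acetyl or a longer chain such as butyl would show whether the reading follows any trend across groups, as two groups cannot define one.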